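The source may report more compounds than this note shows. Statements on the series, on what has been measured and on what is new or still open speak of the compounds shown alone.

Measured so far:
compound 1 `CC1CCCN(c2cc(C(F)(F)F)nn2-c2ccc(S(C)(=O)=O)cn2)C1`: "not determined" (no result reported)
compound 2 `CC1CCCN(c2c(C#N)c(C(F)(F)F)nn2-c2ccc(S(C)(=O)=O)cn2)C1`: 100 ug/mL
compound 3 `CS(=O)(=O)c1ccc(-n2nc(C(F)(F)F)c(C#N)c2NCC2CC2)cc1`: "not determined" (no result reported)

In a physicochemical assay for solubility (a higher number here means a more soluble compound, a lower number a less soluble compound), compound 1 has no number to stand on, and compound 3 is in the same position. Only compound 2 gives a measured result (100 ug/mL), so that single figure is the one anchor for this series.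

The next molecule is compound 4 `CC(C)(C)COc1cc(C(F)(F)F)nn1-c1ccc(S(C)(=O)=O)cn1`, which is built from compound 1 by one swap: neopentyloxy in place of 3-methylpiperidin-1-yl on an aromatic carbon. It sits next to the ring nitrogen, on the same core.

For the measured compounds named here, with no measured step to go on and no value for compound 1, the size of this change cannot be read from the data. A cautious expectation is a moderate step downward from the figure for compound 2 (100 ug/mL), though with wide uncertainty, since one number is thin support.

For compound 4 the expected value in this assay is about 30 ug/mL, with an estimated range from 5 ug/mL to 100 ug/mL.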

Compound 4, solubility: 100 ug/mL
For compound 4 the middle estimate is 3.3-fold (0.52 log units) below the measured one, and the stated range covers the measured number.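

In this assay compound 4 gives 100 ug/mL but compound 1 has no single number, and no step can be read between them. Going by these compounds, whether neopentyloxy in place of 3-methylpiperidin-1-yl changes solubility on the shared core stays open. Nothing shown bears on this result.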